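The compounds below may be only part of what the source reports. "The series", "measured", "known", "first", "only" and "open" are said of these compounds alone.

Measured compounds:
- compound 1, `COc1ccc(C(=O)/C=C/c2cc(-c3cc(OC)c(OC)c(OC)c3)n3nc(-c4ccccc4)cc3n2)cc1`: 79800 nM
- compound 2, `COc1ccc(-c2cc(/C=C/C(=O)c3ccc(OC)c(OC)c3)nc3cc(-c4ccccc4)nn23)cc1`: 48500 nM
- compound 3, `COc1ccc(-c2cc(/C=C/C(=O)c3ccc(C)c(C)c3)nc3cc(-c4ccccc4)nn23)cc1OC`: 46200 nM

Three compounds sharing one core were tested in an ADME assay on HEK293 cells (Homo sapiens) for antiproliferative activity, read by MTT assay, with a stated time of 24 h; a higher number here means a weaker inhibitor, a lower number a stronger inhibitor. Compound 1 gives 79800 nM, the highest of the three numbers, yet its gaps to compound 2 and to compound 3 both fall within the usual scatter, so the three cannot be told apart on these data.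

Compound 4, `COc1cc(-c2cc(/C=C/C(=O)c3ccc(C)cc3)nc3cc(-c4ccccc4)nn23)cc(OC)c1OC`, has not yet been measured in this assay. Relative to compound 1 it carries methyl in place of methoxy on an aromatic carbon. Within the data shown here, no step between two measured compounds with this same difference is available. Among the measured compounds shown here, the only related pair, compound 2 and compound 3, which differ in the number of methoxy or methyl groups on the aryl ketone, show values within the scatter of each other, and nothing else here suggests a large effect of replacing methoxy by methyl.

Compound 4 is therefore expected to lie close to compound 1, with a step of a 1.3-fold lower number from compound 1 to compound 4 (0.12 log units; within the scatter) not clearly beyond the scatter. Compound 4 is estimated at 60000 nM, within a range from 25000 nM to 150000 nM.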

Compound 4, half-maximal inhibitory concentration: 50400 nM
Compound 4: middle estimate off by 1.2-fold (0.08 log units), on the high side; the range from low to high includes it.
By their numbers in this assay, from the lowest: compounds 3, 2, 4 and 1 (each within the scatter of the next).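

Among these compounds, with the rest of the structure held fixed, the change from 4-methoxyphenyl to 4-methylphenyl on the carbonyl gives a 1.6-fold lower number from compound 1 to compound 4 (0.20 log units; within the scatter) in this assay and provides the first comparison in which only one place differs. Among the compounds shown here, at this aromatic carbon, para to a large group, methyl in place of methoxy therefore leaves compound 1 and compound 4 indistinguishable, which the earlier compounds, differing in more than one place, could not show. Nothing available here bears on the reason for this result.

As far as these compounds go, this single pair tests only methoxy and methyl, so it remains open whether an amine or a carboxylic acid at the same carbon would give a step beyond the scatter. From the compounds shown here alone, whether the same swap would behave alike with a different aryl group on the other side of the core also remains open.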